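The source may report more compounds than this note shows. Statements on the series, on what has been measured and on what is new or still open speak of the compounds shown alone.

The compounds below were tested in an assay for inhibition of RAC-alpha serine/threonine-protein kinase (Homo sapiens), read by HTRF, with a stated time of 1 h; on this read-out lower numbers stand for stronger inhibition and higher numbers for weaker inhibition. Compound 1 `O=C(N[C@@H]1CNCC[C@H]1c1ccc(Cl)cc1)c1ccc(-c2ncnc3c2CCC3O)s1` gives only a limit in this assay, > 1000 nM. Compound 2 `CC(=O)NCC[C@@H]1C[C@@H](c2ccc(F)c(F)c2)[C@H](NC(=O)c2cc(-c3c(Cl)cnn3C)c(Cl)o2)CN1` gives 2.49 nM. Compound 3 `Cn1ncc(Cl)c1-c1cc(C(=O)N[C@@H]2CN[C@H](CCN3CCC(O)CC3)C[C@H]2c2ccc(Cl)c(Cl)c2)oc1Cl` gives 5.99 nM, the higher of the two numbers measured, and the gap separating it from compound 2 lies beyond the usual scatter of this assay. For compound 1 the reading is a limit, so it cannot be placed on this scale.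

Compound 4 `Cn1ncc(Cl)c1-c1cc(C(=O)N[C@@H]2CN[C@H](CC(N)=O)C[C@H]2c2ccc(Cl)c(Cl)c2)oc1Cl` has not yet been measured. It differs from compound 3 in one place: carbamoyl in place of (4-hydroxypiperidin-1-yl)methyl on a saturated chain carbon bound to a saturated ring carbon. Going by the values given here, no comparable change has been measured, so no step can be quoted for it. Compound 2 carries its own amide-bearing chain at a related position and gives 2.49 nM, which suggests that an amide on this chain is tolerated. The step from compound 3 to compound 4 is therefore expected to be small, a 1.3-fold higher number from compound 3 to compound 4 (0.13 log units; within the scatter), and in neither direction clearly beyond the scatter. For compound 4 a value of 8 nM is estimated, with a likely range from 2.5 nM to 25 nM.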

Compound 4, half-maximal inhibitory concentration: 3.24 nM
Compound 4: middle estimate off by 2.5-fold (0.39 log units), on the high side; the range from low to high includes it.
By their numbers in this assay, from the lowest: compounds 2, 4 and 3 (each within the scatter of the next, the first and the last beyond it). At a limit, above all of these: compound 1.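

In this assay, carbamoyl in place of (4-hydroxypiperidin-1-yl)methyl on a saturated chain carbon bound to a saturated ring carbon gives a 1.8-fold lower number from compound 3 to compound 4 (0.27 log units; within the scatter). Going by these compounds alone, this is the first measured change at this place, and it shows that a group of 3 heavy atoms with no ring can stand where a group of 8 heavy atoms with a six-membered ring stood, without a change beyond the scatter. The measurements shown give no explanation for this result.

From the compounds shown here alone, how a carboxylic acid or a primary amine would read in place of the carbamoyl remains open. So does the effect of a dimethylcarbamoyl group, or of a plain methyl group, at this same place on the chain.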